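The source may hold more compounds than are shown below. What is called first, only, known or untested is meant among the compounds shown, and "the series" means these compounds.

Measured in an ADME assay on the whole organism with Oryza sativa as the target, tested at 1 uM; on this read-out higher numbers stand for a weaker effect at the one concentration tested and lower numbers for a stronger effect:

compound 1, `C[C@@H](NC(=O)Nc1ccccc1Cl)c1ccccc1`, 103%
compound 2, `C[C@@H](NC(=O)Nc1cccc(Cl)c1)c1ccccc1`, 91%
compound 3, `C[C@@H](NC(=O)Nc1ccccc1Br)c1ccccc1`, 100%

Compound 1 and compound 2 share the same atoms joined differently; the difference between the two cores is not broken down here. Compound 3 is made from compound 1 by bromo in place of chloro on an aromatic carbon, and in this assay that gave a number 3 percentage points lower from compound 1 to compound 3 (within the scatter). Compound 4, `C[C@@H](NC(=O)Nc1cccc(Br)c1)c1ccccc1`, is not yet measured. It is made from compound 2 by bromo in place of chloro on an aromatic carbon, the same kind of change, but here the place is meta to a large group where in compound 3 it is ortho to a large group. From compound 2 to compound 4 the expected step is a number 3 percentage points lower from compound 2 to compound 4 (within the scatter), resting on the step seen from compound 1 to compound 3, a number 3 percentage points lower from compound 1 to compound 3 (within the scatter). The estimate for compound 4 is 88%, between 78% and 98%.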

Compound 4, a percentage reported as activity, at one concentration (the size of the read-out at that concentration, not a potency): 100%
Compound 4: middle estimate off by 12 percentage points, on the low side; the whole stated range lies below it.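

Putting bromo in place of chloro on an aromatic carbon gave, in this assay, a number 9 percentage points higher from compound 2 to compound 4 (within the scatter). Set beside the earlier case, the two steps cannot be told apart: the same change on two cores in this assay, a number 3 percentage points lower (within the scatter) from compound 1 to compound 3 and a number 9 percentage points higher (within the scatter) from compound 2 to compound 4, 12 percentage points apart, within the scatter of two such steps

So on these two cores the change behaves alike, in that neither step stands out from the ordinary spread of repeat measurements, but this does not show that the change truly has no effect, nor that the same would hold on any other core. The compounds shown leave open whether a group other than these two halogens, such as fluoro, methoxy, an amine or a carboxylic acid, would shift the read-out on this aromatic ring by more than the scatter.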